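The source may report more compounds than this note shows. Statements on the series, on what has been measured and on what is new or still open speak of the compounds shown alone.

Measured compounds in the series:

compound 1 `CCN(CC)c1cc(N)c2cc(OC)c(OC)cc2n1`: 2.93 nM
compound 2 `COc1cc2nc(N3CCN(c4ccccc4)CC3)cc(N)c2cc1OC`: 1.72 nM
compound 3 `COc1cc2nc(N3CCN(c4nccc(C)n4)CC3)cc(N)c2cc1OC`: 0.63 nM

In an assay on brain for displacement of a labelled ligand from Adrenergic receptor alpha-1 (Rattus norvegicus) (a lower number here means a stronger inhibitor, a higher number a weaker inhibitor), compound 1 gives 2.93 nM, the highest of the three numbers shown; its gap to compound 2, which in this assay gives 1.72 nM, is within the scatter and carries no order. Compound 3 in this assay gives 0.63 nM, and this gap to compound 1 lies beyond the scatter. Among the measured compounds shown here, the single step between measured compounds that differ in one place is a 2.7-fold lower number from compound 2 to compound 3 (0.44 log units; beyond the scatter); it concerns the aryl on an amine nitrogen in a ring and leaves the side of compound 1 with the diethylamino untouched.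

Compound 4 `COc1cc2nc(N(C)C)cc(N)c2cc1OC` is not yet measured. It differs from compound 1 in one place: dimethylamino in place of diethylamino on an aromatic carbon. For the measured compounds named here, no measured pair bears on this change; the one measured step is at another part of the core, and nothing measured shows how swapping diethylamino for dimethylamino at this place moves the number. The step in this assay is therefore expected to be a 1.4-fold higher number from compound 1 to compound 4 (0.14 log units; within the scatter), nothing beyond the scatter. Compound 4 is estimated at 4 nM, with a range from 1.5 nM to 12 nM.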

Compound 4, inhibition constant: 11.4 nM
For compound 4 the middle estimate is 2.9-fold (0.45 log units) below the measured one, and the stated range covers the measured number.
By their numbers in this assay, from the lowest: compound 3; then compounds 2 and 1 (each within the scatter of the next); then compound 4.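

In this assay, among the compounds shown here, the step of a 3.9-fold higher number from compound 1 to compound 4 (0.59 log units; beyond the scatter) is the first reading of a change between two open-chain amines at this place, on the aromatic carbon next to the ring nitrogen. It shows that this place is sensitive to the alkyl groups on the amine: within this pair, the group of 3 heavy atoms, dimethylamino, gives the higher number, and the group of 5 heavy atoms, diethylamino, gives the lower one. The two groups have the same counts of hydrogen-bond donors and acceptors and the same net charge, so those counts do not separate them, and no supporting measurement explains the shift.

With only two open-chain amines compared at this place, the pair gives a direction for this one change and no trend with chain length, so a longer chain such as dipropylamino, or a simple amino group or a single ethylamino group, could either extend this direction or break it. From the compounds shown here alone, it also remains open whether a step of this size would persist if the two methoxy groups on the shared core were replaced, for example by ethoxy groups.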